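From Allyl to 4-Fluorobenzyl in an Antiproliferative Compound

This account rests on a few compounds, and the source may have more. Where it says the series, first, only, none or still open, it means among the compounds named here.

Among the measured compounds shown here, in a functional assay on WHCO1 cells (Homo sapiens) for antiproliferative activity, read by MTT assay, with a stated time of 48 h (a lower number here means a stronger inhibitor, a higher number a weaker inhibitor), compound 1 `C=CCSSC=CC[S+]([O-])Cc1ccc(OC)cc1` gives 7400 nM as the only actual number so far. Compound 2 `COc1ccc(CS/C=C/C[S+]([O-])Cc2ccc(OC)cc2)cc1` gives > 200000 nM as its reading, which is a limit of the assay and not a number. Compound 1 is thus the sole measured reference point, and it lies on the stronger side of that limit.

Compound 3 `COc1ccc(C[S+]([O-])CC=CSSCc2ccc(F)cc2)cc1` has not yet been measured. The change 4-fluorophenyl in place of vinyl on a saturated chain carbon bound to a sulfur puts 4-fluorophenyl in place of vinyl on a saturated chain carbon bound to a sulfur and reads as allyl to 4-fluorobenzyl. For the measured compounds named here, no measured step guides this change, so the expectation rests on compound 1 at 7400 nM alone. In this assay no shift beyond the scatter is expected, and the estimate is a 1.5-fold lower number from compound 1 to compound 3 (0.17 log units; within the scatter) as a slight lean toward stronger inhibition. Compound 3 is expected at 5000 nM with an estimated range from 1800 nM to 14000 nM in this measurement.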

Compound 3, half-maximal inhibitory concentration: 16000 nM
For compound 3 the middle estimate is 3.2-fold (0.51 log units) below the measured one, and the stated range ends below it.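

In this assay, among the compounds shown here, replacing allyl with 4-fluorobenzyl on a saturated chain carbon bound to a sulfur gives a 2.2-fold higher number from compound 1 to compound 3 (0.33 log units; beyond the scatter) as the first step that can be read at this position. The step is modest and runs toward weaker inhibition, so the larger group with its aromatic ring costs some activity at this place. Even so, compound 3 still gives a real number of 16000 nM.

On these data alone, a single step cannot show whether the change comes from the fluorine or from the benzyl ring itself, and how a plain benzyl, a longer chain or an amine would read at this place remains open. The reading of compound 2 is a limit and not a number, so no step to it can be read: the limit of > 200000 nM in this assay, at which 1 of the 3 values shown sits.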